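Replacing 1H-benzimidazol-5-yl with 1H-indol-4-yl: working notes

A few compounds are considered here, and "the series" means these few. Any claim that something is new, unique, unknown or untested is made for them only; others in the source may bear on it.

Of the compounds shown here, two on one shared core have numbers so far in a functional assay on DU-145 cells (Homo sapiens) for inhibition, read by trypan blue exclusion, with a stated time of 72 h (on this read-out higher numbers stand for weaker inhibition and lower numbers for stronger inhibition), and they lie well apart. Compound 2 (`Cn1c(=O)c(S(=O)(=O)c2ccc(F)cc2)cc2cnc(Nc3ccc4[nH]cnc4c3)nc21`) stands at 10000 nM as the higher of the two numbers. Compound 1 (`Cn1c(=O)c(S(=O)(=O)c2ccc(F)cc2F)cc2cnc(Nc3cccc4[nH]ccc34)nc21`) stands at 750 nM and the gap between the two lies beyond the scatter.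

Compound 3 (`Cn1c(=O)c(S(=O)(=O)c2ccc(F)cc2)cc2cnc(Nc3cccc4[nH]ccc34)nc21`) is reached from compound 2 by one change (1H-indol-4-yl in place of 1H-benzimidazol-5-yl on a nitrogen on an aromatic ring), with 1H-indol-4-yl in place of 1H-benzimidazol-5-yl on a nitrogen on an aromatic ring. Among the compounds with values here, no measured pair shows this change alone. Within the data shown here, the only guide is compound 1, which also carries 1H-indol-4-yl and gives 750 nM in this assay as the single number for that group. One compound is thin support, so the range is kept wide.

A step toward stronger inhibition and beyond the scatter is expected, with the estimated size (an 11-fold lower number from compound 2 to compound 3 (1.05 log units; beyond the scatter)) as the working figure. For compound 3 the estimated value is 900 nM with an expected range from 300 nM to 3500 nM in this read-out.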

Compound 3, half-maximal inhibitory concentration: 750 nM
Estimate against measurement, compound 3: 1.2-fold (0.08 log units) above; the measured number falls inside the stated range.
By their numbers in this assay, from the lowest: compounds 1 and 3 (each within the scatter of the next); then compound 2.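

In this assay, the exchange of 1H-benzimidazol-5-yl for 1H-indol-4-yl on a nitrogen on an aromatic ring now stands alone in a matched pair, and it gives a 13-fold lower number from compound 2 to compound 3 (1.12 log units; beyond the scatter), a large step from this one place. Hydrogen in place of fluoro on an aromatic carbon, read with 1H-indol-4-yl in place, gives no change at the digits printed from compound 1 to compound 3 (within the scatter), so this fluoro does not account for the gap first seen between compound 1 and compound 2, and the group on the nitrogen does. Nothing at hand gives a reason for either step.

Left open is how other groups on that nitrogen would read against compound 3, for example 1H-indol-5-yl or a phenyl ring carrying a carboxylic acid or an amine. Also open, as far as these compounds go, is whether the exchange of fluoro for hydrogen reads the same alongside 1H-benzimidazol-5-yl, and what a longer chain such as ethyl would do in place of the methyl on the shared core.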